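Dimethoxy pattern on the cinnamamide arm of the anilinoquinazoline series

The source may report more compounds than this note shows. Statements on the series, on what has been measured and on what is new or still open speak of the compounds shown alone.

Measured so far:
compound 1 `COc1ccc(OC)c(/C=C/C(=O)Nc2cc3c(Nc4ccc(F)c(Cl)c4)ncnc3cc2OC)c1` in a functional assay on MCF7 cells (Homo sapiens) for cytotoxicity, read by MTT assay, with a stated time of 72 h (on this read-out higher numbers stand for weaker inhibition and lower numbers for stronger inhibition), gives 34300 nM
compound 2 `COc1ccc(OC)c(/C=C/C(=O)Nc2cc3c(Nc4ccc(F)c(Cl)c4)ncnc3cc2O[C@H]2CCOC2)c1` in this assay gives 36300 nM

Compound 2 gives the higher of the two numbers, but the gap to compound 1, a 1.1-fold higher number from compound 1 to compound 2 (0.02 log units; within the scatter), lies within the scatter. Compound 3 `COc1cc(/C=C/C(=O)Nc2cc3c(Nc4ccc(F)c(Cl)c4)ncnc3cc2O[C@H]2CCOC2)cc(OC)c1` differs from compound 2 by 3,5-dimethoxyphenyl in place of 2,5-dimethoxyphenyl on a double-bonded chain carbon bound to a double-bonded chain carbon. For the measured compounds named here, the only measured step concerns the oxygen substituent on the shared core, not the dimethoxyphenyl, so no measured step bears on this change. With no guide, compound 3 is expected to stay close to compound 2, a step of a 1.0-fold lower number from compound 2 to compound 3 (0.02 log units; within the scatter), estimated at 35000 nM with a range of 12000 nM to 100000 nM in this assay.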

Compound 3, half-maximal inhibitory concentration: 30300 nM
Compound 3: the middle estimate sits 1.2-fold (0.06 log units) above what was measured; the measured number falls inside the stated range.
By their numbers in this assay, from the lowest: compounds 3, 1 and 2 (each within the scatter of the next).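

Exchanging 2,5-dimethoxyphenyl for 3,5-dimethoxyphenyl on a double-bonded chain carbon bound to a double-bonded chain carbon gives the only step shown at this position: in this assay, it reads a 1.2-fold lower number from compound 2 to compound 3 (0.08 log units; within the scatter). These two methoxy patterns therefore cannot be told apart on this read-out. No available evidence bears on this result.

Going by these compounds, whether any replacement on this phenyl ring can shift the number beyond the scatter remains open. A dimethylamino group or a carboxylic acid in place of the methoxy groups would test this.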